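Nucleoside series: ring swap from compound 2 to compound 3

A few compounds are considered here, and "the series" means these few. Any claim that something is new, unique, unknown or untested is made for them only; others in the source may bear on it.

The series shares one core and varies the aryl ring on a saturated chain carbon bound to a nitrogen on an aromatic ring. Compound 1 `OC[C@H]1O[C@@H](n2cnc3c(NCc4cccc(Br)c4)ncnc32)[C@H](O)[C@@H]1O` carries 3-bromophenyl there; in a functional assay on K562 cells (Homo sapiens) for antiproliferative activity, with a stated time of 72 h (on this read-out lower numbers stand for stronger inhibition and higher numbers for weaker inhibition), compound 1 gives 19700 nM. Compound 2 `COc1cccc(CNc2ncnc3c2ncn3[C@@H]2O[C@H](CO)[C@@H](O)[C@H]2O)c1OC` carries 2,3-dimethoxyphenyl. In this assay compound 2 reaches only a limit of the assay, > 166000 nM, so no number is known for it (the limit of > 166000 nM in this assay, at which 1 of the 2 values shown sits). The step of an at least 8.4-fold higher number from compound 1 to compound 2 (0.92 log units; beyond the scatter) is the only measured one that bears on the next change.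

Compound 3 `Cc1ccc(O)c(CNc2ncnc3c2ncn3[C@@H]2O[C@H](CO)[C@@H](O)[C@H]2O)c1` differs from compound 2 by 2-hydroxy-5-methylphenyl in place of 2,3-dimethoxyphenyl on a saturated chain carbon bound to a nitrogen on an aromatic ring. No measured step sets a hydroxyl-bearing ring against a dimethoxy-bearing one, so the direction is open; the departure from 2,3-dimethoxyphenyl gives some reason to expect a partial return toward compound 1 at 19700 nM. The step expected here is an at least 2.3-fold lower number from compound 2 to compound 3 (0.37 log units; beyond the scatter). Compound 3 is estimated at 70000 nM in this assay, with a range from 20000 nM to 250000 nM and a fair chance that only a limit is again reported.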

Compound 3, half-maximal inhibitory concentration: 16500 nM
Compound 3: the middle estimate sits 4.2-fold (0.63 log units) above what was measured; the whole stated range lies above it.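

Position note: the aryl ring on the saturated chain carbon bound to a nitrogen on an aromatic ring can change sharply without loss being the general outcome. In this assay, the change to 2-hydroxy-5-methylphenyl gives an at least 10-fold lower number from compound 2 to compound 3 (1.00 log units; beyond the scatter), so the series recovers from the dimethoxy ring, though the size of that step is bounded on one side only: compound 2 remains a limit, not a number: the limit of > 166000 nM in this assay, at which 1 of the 3 values shown sits.

The second step, a 1.2-fold lower number from compound 1 to compound 3 (0.08 log units; within the scatter), shows that 2-hydroxy-5-methylphenyl and 3-bromophenyl are not separated on this read-out, so bromine is not required for this level of activity.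

Compound 3 changes the hydroxyl and methyl together, so their separate shares stay unresolved, as do those of the two methoxy groups in compound 2. Also open, from the compounds shown here alone, is whether an amine or a carboxylic acid on the ring would hold this level.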